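A few compounds are considered here, and "the series" means these few. Any claim that something is new, unique, unknown or untested is made for them only; others in the source may bear on it.

Compound 1 `CCCCCCCCN(C)C(=O)Cn1cc(Cc2cnc(=O)n(CC(=O)O)c2)c(=O)nc1SCc1ccc(F)cc1`: 27%
Compound 2 `CCCCCCCCN(C)C(=O)Cn1cc(Cc2cnc(=O)n(CCO)c2)c(=O)nc1SCc1ccc(F)cc1`: 36%
Compound 3 `CCCCCCCCN(C)C(=O)Cn1cc(Cc2cnc(=O)n(CC(=O)N3CCOCC3)c2)c(=O)nc1SCc1ccc(F)cc1`: 36%

All three were examined in a functional assay on a cell-free system (plasma, Oryctolagus cuniculus) for inhibition of platelet-activating factor acetylhydrolase (Homo sapiens), tested at 100 nM; on this read-out lower numbers stand for less inhibition and higher numbers for more inhibition at the one concentration tested (going by the name of the read-out). Among them compound 3 stands level with compound 2 as far as the reported figures go, the two together being the highest of the three numbers, while compound 1 lies furthest from compound 3, by a number 9 percentage points higher from compound 1 to compound 3 (within the scatter), a gap that stays within the scatter.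

Compound 4 `CCCCCCCCN(C)C(=O)Cn1cc(Cc2cnc(=O)n(CC(=O)N3CCNC(=O)C3)c2)c(=O)nc1SCc1ccc(F)cc1` is the next member. It differs from compound 3 in one place: 3-oxopiperazin-1-yl in place of morpholin-4-yl on a carbonyl carbon.

The steps already seen at this end of the molecule bear on the change. From compound 1 to compound 2 the read-out moved by a number 9 percentage points higher from compound 1 to compound 2 (within the scatter), from compound 1 to compound 3 by a number 9 percentage points higher from compound 1 to compound 3 (within the scatter), and from compound 2 to compound 3 by no change at the digits printed from compound 2 to compound 3 (within the scatter); none of these left the scatter. Varying the group on this carbonyl carbon has so far produced no step beyond the scatter, so for compound 4 the step is expected to be no change at the digits printed from compound 3 to compound 4 (within the scatter), that is, no movement beyond the scatter in either direction. Compound 4 is therefore estimated at 36%, with a range from 24% to 48%.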

Compound 4, a percentage reported as inhibition, at one concentration (the size of the read-out at that concentration, not a potency): 55%
The estimate for compound 4 lay 19 percentage points below the measured number; the measured number lies above the stated range.
By their numbers in this assay, from the lowest: compounds 1, 2 and 3 (each within the scatter of the next); then compound 4.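

In this assay, going by these compounds alone, the group on this carbonyl carbon now makes a difference: 3-oxopiperazin-1-yl in place of morpholin-4-yl gives a number 19 percentage points higher from compound 3 to compound 4 (beyond the scatter), the first step at this end of the molecule to leave the scatter. The same group also stands clear of the other two compounds, with a number 19 percentage points higher from compound 2 to compound 4 (beyond the scatter) where it replaces hydroxymethyl on the saturated chain carbon and a number 28 percentage points higher from compound 1 to compound 4 (beyond the scatter) where it replaces hydroxy on the carbonyl carbon. No measurement at hand ties this rise to any feature of the group.

The compounds shown leave open whether the rise needs the ring carbonyl, which a plain piperazine amide would test, or the amide hydrogen, which a methyl group on that ring nitrogen would replace. Going by these compounds, with one concentration per compound, their potencies also remain open.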